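Methoxy to hydroxy on the core of compound 1

This account rests on a few compounds, and the source may have more. Where it says the series, first, only, none or still open, it means among the compounds named here.

Measured so far in an assay on isolated protein for binding affinity to prostaglandin E2 receptor EP1 subtype (Mus musculus); a higher number here means a weaker inhibitor, a lower number a stronger inhibitor:
compound 1 `CCCCOc1ccc(C(=O)n2c(C)c(CC(=O)O)c3cc(OC)ccc32)cc1` — > 10000 nM
compound 2 `CCCCOc1ccc(C(=O)n2c(C)c(CCCCC(=O)O)c3cc(OC)ccc32)cc1` — > 10000 nM

Compound 1 gives > 10000 nM in this assay, which is a limit of the assay and not a number. Compound 2 likewise gives > 10000 nM, also a limit. For the measured compounds named here, the only measured step, a step that the two limits leave unreadable from compound 1 to compound 2, has no readable size because of the limit of > 10000 nM in this assay, at which 2 of the 2 values shown sit. Compound 1 therefore stands at a limit only, with no measured neighbour that gives a number.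

Compound 3 `CCCCOc1ccc(C(=O)n2c(C)c(CC(=O)O)c3cc(O)ccc32)cc1` differs from compound 1 by hydrogen in place of methyl on an oxygen on an aromatic ring, that is methoxy to hydroxy. No measured step bears on this change, and the one step that is shown is unreadable. Nothing in the series grounds a movement in either direction beyond the scatter, and the starting point is itself a limit. Compound 3 is thus expected to sit at about 15000 nM, with a range from 3000 nM to 60000 nM. The expected step is a step that the limit leaves unreadable from compound 1 to compound 3, most likely again reported as a limit.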

Compound 3, inhibition constant: > 10000 nM
Compound 3 ended at the assay's limit; the forecaster's own chance of this, stated with the estimate: 80%; the middle value does not contradict the limit.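

No new step can be read: the pair compound 1 and compound 3 gives only limits, not numbers, because of this: the limit of > 10000 nM in this assay, at which 3 of the 3 values shown sit.

The compounds shown leave open which change to the shared core, if any, would give a readable number in this assay rather than a limit.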